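Series notes: methoxy added to the aryl of compound 1

The source may hold more compounds than are shown below. What is called first, only, known or untested is meant among the compounds shown, and "the series" means these compounds.

Measured in a functional assay on ACHN cells (Homo sapiens) for cytotoxicity, read by sulforhodamine B assay, with a stated time of 48 h, tested at 0.01 uM; a lower number here means a stronger effect, a higher number a weaker effect of the compound at the concentration tested:
- compound 1 `COc1ccc(-c2cc(/C=C/C(=O)c3ccc(N)cc3)[nH]n2)cc1` gives 103%
- compound 2 `COc1cc(-c2cc(/C=C/C(=O)c3ccc(Cl)c(Cl)c3)[nH]n2)cc(OC)c1OC` gives 107%
- compound 3 `COc1ccc(C(=O)/C=C/c2cc(-c3cc(OC)c(OC)c(OC)c3)n[nH]2)cc1` gives 102%

All three numbers sit close together. Compound 1 is flanked on one side by compound 3 and on the other by compound 2, and both of those lie within the scatter of compound 1, so no order among them can be read. Within the data shown here, the one step that can be computed, a number 5 percentage points lower from compound 2 to compound 3 (within the scatter), exchanges the aryl on the carbonyl carbon and leaves the number within the scatter as well.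

Compound 4 `COc1ccc(-c2cc(/C=C/C(=O)c3ccc(N)cc3)[nH]n2)cc1OC` is not yet measured. It differs from compound 1 by methoxy in place of hydrogen on an aromatic carbon. Among the measured compounds shown here, no measured step touches this position on the shared core, so the step at the carbonyl side is the only guide, and it was flat. Nothing in the data points to a shift beyond the scatter for compound 4; the step is expected to be no change at the digits printed from compound 1 to compound 4 (within the scatter). Compound 4 is therefore estimated at 103%, between 93% and 113%.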

Compound 4, a percentage reported as activity, at one concentration (the size of the read-out at that concentration, not a potency): 93%
Beside the measured number, compound 4's estimate is 10 percentage points above it; measured number inside the range.
By their numbers in this assay, from the lowest: compounds 4, 3, 1 and 2 (each within the scatter of the next, the first and the last beyond it).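

Among these compounds, this is the first measured step at this position, on an aromatic carbon ortho to a methoxy group and meta to a large group: in this assay, methoxy in place of hydrogen gives a number 10 percentage points lower from compound 1 to compound 4 (within the scatter). The earlier compounds shown here offered only a step on the carbonyl side, so this adds a reading from the aryl on the other side of the shared core, and that reading also does not separate from the scatter at the concentration tested. No supporting data bear on this step.

Going by these compounds, it remains open whether ethoxy, hydroxy or fluorine on this same aromatic carbon would carry the number beyond the scatter. Also open, on these data alone, is whether methoxy here would read the same if the amine on the carbonyl-side aryl gave way to an acetamide.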